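An Aryl Swap on the Five-Membered Ring Nitrogen

The source may report more compounds than this note shows. Statements on the series, on what has been measured and on what is new or still open speak of the compounds shown alone.

Two compounds have so far been measured in a functional assay on MKN-45 cells (Homo sapiens) for cytotoxicity, read by MTT assay, with a stated time of 72 h; a higher number here means a weaker inhibitor, a lower number a stronger inhibitor:

Compound 1 `COc1cc2c(Oc3ccc(NC(=O)c4nnn(-c5ccc(F)c(F)c5)c4C(F)(F)F)cc3F)ccnc2cc1OCCCN1CCC(C)CC1` gives 50 nM.
Compound 2 `COc1cc2c(Oc3ccc(NC(=O)c4nnn(-c5ccc(C)cc5)c4C(F)(F)F)cc3F)ccnc2cc1OCCCN1CCN(C)CC1` gives 140 nM.

Of these two, compound 2 gives the higher number, meaning it is the weaker of the pair, and its gap to compound 1 lies beyond the usual scatter of repeated measurements.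

Compound 3 `COc1cc2c(Oc3ccc(NC(=O)c4nnn(-c5ccc(F)c(F)c5)c4C(F)(F)F)cc3F)ccnc2cc1OCCCN1CCN(C)CC1` has not yet been measured. It differs from compound 2 in one place: 3,4-difluorophenyl in place of 4-methylphenyl on an aromatic nitrogen. For the measured compounds named here, no pair of measured compounds isolates this single change. Compound 1 carries the same 3,4-difluorophenyl group, but it also differs from compound 3 in the amine at the end of the chain. So the value of compound 1, 50 nM, only offers a rough orientation.

On that basis, the expectation for the step from compound 2 to compound 3 in this assay is a moderate move toward a lower number, a 1.9-fold lower number from compound 2 to compound 3 (0.27 log units; within the scatter), of about the size seen between the two measured compounds. Compound 3 is therefore estimated to give 75 nM, with a likely range from 35 nM to 180 nM.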

Compound 3, half-maximal inhibitory concentration: 90 nM
Estimate against measurement, compound 3: 1.2-fold (0.08 log units) below; low and high end bracket the measured number.
By their numbers in this assay, from the lowest: compounds 1, 3 and 2 (each within the scatter of the next, the first and the last beyond it).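

In this assay, for the compounds shown here, with the 4-methylpiperazin-1-yl end of the chain held constant, 3,4-difluorophenyl in place of 4-methylphenyl on the aromatic nitrogen gives a 1.6-fold lower number from compound 2 to compound 3 (0.19 log units; within the scatter) and so this aryl swap, read alone for the first time, does not clear the usual scatter. With the 3,4-difluorophenyl group held constant, the change at the chain end gives a 1.8-fold higher number from compound 1 to compound 3 (0.26 log units; within the scatter) and so it also stays inside the scatter, which means that the clear gap between compound 1 and compound 2, two compounds that differ in both places, is not matched by either change taken alone. Nothing available here explains either step.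

The compounds shown leave open whether a plain phenyl, a 4-methoxyphenyl or a saturated cyclohexyl ring on that same nitrogen, or a morpholine at the end of the chain, would produce a step beyond the scatter. Going by these compounds alone, they also cover only two groups at each of these two places, so they cannot show how far either place tolerates change in general.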